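Methoxy for fluoro on the core: compound 4

This account rests on a few compounds, and the source may have more. Where it says the series, first, only, none or still open, it means among the compounds named here.

The series shares one core, seen in compound 1 `CC1CCN(c2c(S(=O)(=O)c3ccc(F)cc3)cnc3ccc(F)cc23)CC1`, and varies the groups around it. In an assay on isolated protein for displacement of a labelled ligand from metabotropic glutamate receptor 5 (Homo sapiens), with a stated time of 60 min, tested at 1 uM (a lower number here means less inhibition, a higher number more inhibition at the concentration tested (going by the name of the read-out)), compound 1 gives 87%, the second highest of the three numbers in hand. Compound 2 `COc1ccc(S(=O)(=O)c2cnc3ccc(F)cc3c2N2CCC(C)CC2)cc1` gives 85%, and compound 3 `CC1CCN(c2c(S(=O)(=O)c3ccc(Cl)c(Cl)c3)cnc3ccc(F)cc23)CC1` gives 91%. The step of a number 2 percentage points lower from compound 1 to compound 2 (within the scatter), the step of a number 4 percentage points higher from compound 1 to compound 3 (within the scatter) and the step of a number 6 percentage points higher from compound 2 to compound 3 (within the scatter) all stay within the scatter, so the three measured compounds cannot be ranked against each other.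

Compound 4 `COc1ccc2ncc(S(=O)(=O)c3ccc(F)cc3)c(N3CCC(C)CC3)c2c1` differs from compound 1 by methoxy in place of fluoro on an aromatic carbon. Among the measured compounds shown here, the one measured step with the same exchange of groups is a number 2 percentage points lower from compound 1 to compound 2 (within the scatter), made at a different aromatic carbon, so it bears on the new step only loosely. Since a number 2 percentage points lower from compound 1 to compound 2 (within the scatter) and a number 4 percentage points higher from compound 1 to compound 3 (within the scatter) both stay within the scatter, no step beyond it is expected for compound 4. The expected step for compound 4 is a number 1 percentage points lower from compound 1 to compound 4 (within the scatter). Compound 4 is therefore estimated at 86%, with a range from 74% to 95%.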

Compound 4, a percentage reported as inhibition, at one concentration (the size of the read-out at that concentration, not a potency): 27%
Compound 4: the middle estimate sits 59 percentage points above what was measured; the measured number lies below the stated range.
By their numbers in this assay, from the lowest: compound 4; then compounds 2, 1 and 3 (each within the scatter of the next).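

In this assay, methoxy in place of fluoro on the six-membered aromatic ring of carbon only, part of the fused system, gives a number 60 percentage points lower from compound 1 to compound 4 (beyond the scatter). The same exchange at a different aromatic carbon gives a number 2 percentage points lower from compound 1 to compound 2 (within the scatter), so the outcome of this exchange depends on where it is made, and the position in compound 4 is far less forgiving of it than that other carbon. Nothing in hand accounts for the loss.

As far as these compounds go, whether the loss is specific to methoxy or extends to other groups at this carbon, such as chloro, hydroxy, ethoxy or an amine, remains open, as does the outcome with plain hydrogen there. Also open, from the compounds shown here alone, is whether 3,4-dichlorophenyl on the sulfonyl sulfur, as in compound 3, would hold up alongside methoxy on the core.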